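Shrinking a Saturated Ring on the Shared Core

The source may report more compounds than this note shows. Statements on the series, on what has been measured and on what is new or still open speak of the compounds shown alone.

Measured so far, in an assay on BV-2 cells for positive allosteric modulation of metabotropic glutamate receptor 5 (Mus musculus), read by Griess assay, with stated times of 1 h and 24 h; on this read-out lower numbers stand for stronger inhibition and higher numbers for weaker inhibition:
- Compound 1 `O=C(Nc1nc2ccccc2[nH]1)c1cccc(C(F)(F)F)c1` gives 12000 nM
- Compound 2 `O=C(Nc1nc2ccccc2[nH]1)c1ccncc1` gives 49000 nM
- Compound 3 `O=C(Nc1nc2ccccc2[nH]1)C1CCCCC1` gives 42000 nM

Compound 3 sits second highest of the three numbers in this assay. Its nearest neighbour is compound 2, whose value lies within the usual scatter of it; compound 1 stands furthest away, with a clearly lower number that lies beyond the scatter.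

The next compound, compound 4 `O=C(Nc1nc2ccccc2[nH]1)C1CCC1`, differs from compound 3 in a single place: cyclobutyl in place of cyclohexyl on a carbonyl carbon. Among the measured compounds shown here, the one measured step that touches the same position is a 1.2-fold lower number from compound 2 to compound 3 (0.07 log units; within the scatter), which left the number essentially unchanged when a flat aromatic ring was swapped for a saturated one. For the measured compounds named here, no measured step exchanges one saturated ring for a smaller one, so there is no direct precedent for this particular change.

On that basis the expected step is a 1.1-fold higher number from compound 3 to compound 4 (0.03 log units; within the scatter), that is, no movement beyond the scatter. Compound 4 is therefore estimated at 45000 nM, with a range from 15000 nM to 130000 nM.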

Compound 4, half-maximal inhibitory concentration: 15000 nM
The estimate for compound 4 lay 3.0-fold (0.48 log units) above the measured number; the measured number falls inside the stated range.
By their numbers in this assay, from the lowest: compounds 1 and 4 (each within the scatter of the next); then compounds 3 and 2 (each within the scatter of the next).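

In this assay, the size of a saturated ring on this carbonyl carbon does matter: cyclobutyl in place of cyclohexyl gives a 2.8-fold lower number from compound 3 to compound 4 (0.45 log units; beyond the scatter) and so moves the number, whereas pyridin-4-yl to cyclohexyl gave a 1.2-fold lower number from compound 2 to compound 3 (0.07 log units; within the scatter) and did not. Cyclobutyl in place of pyridin-4-yl gives a 3.3-fold lower number from compound 2 to compound 4 (0.51 log units; beyond the scatter), so having a saturated ring here does not by itself set the number, since compound 3 and compound 4 both carry one. Nothing measured explains why these two rings differ.

With only two saturated ring sizes shown, it remains open whether cyclopentyl would fall with cyclobutyl or with cyclohexyl, and whether cyclopropyl would lower the number further. Also open, from the compounds shown here alone, is how an amine or a hydroxyl group on the cyclobutyl ring would change the number.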